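Pyrimidine for phenyl on the thioether side chain

The source may hold more compounds than are shown below. What is called first, only, known or untested is meant among the compounds shown, and "the series" means these compounds.

Measured compounds:
Compound 1 `CC(Sc1nc2c(cnn2C)c(=O)n1-c1ccc(CCO)cc1)c1ccccc1`: 360 nM
Compound 2 `CC(C)C(Sc1nc2c(cnn2C)c(=O)n1-c1ccccc1)c1ccccc1`: 380 nM
Compound 3 `CCC(Sc1nc2c(cnn2C)c(=O)n1-c1ccccc1)c1ccccc1`: 150 nM

Compound 3 gives the lowest number of the three in an assay on isolated protein for inhibition of aldehyde dehydrogenase 1A1 (Homo sapiens) (on this read-out higher numbers stand for weaker inhibition and lower numbers for stronger inhibition), and its distance to compound 1 and to compound 2 lies beyond the scatter in each case. Compound 4 `CC(Sc1nc2c(cnn2C)c(=O)n1-c1ccccc1)c1cncnc1` has not yet been measured in this assay. It differs from compound 3 by 1-(pyrimidin-5-yl)ethyl in place of 1-phenylpropyl on a sulfur. Among the compounds with values here, only one measured step touches this region: the step of a 2.5-fold lower number from compound 2 to compound 3 (0.40 log units; beyond the scatter), which concerns the branching of the saturated chain on the sulfur and shows that the chain there matters modestly. Compound 1 and compound 3 differ in two places, so their values only show that the two together shift the number by a modest amount. Within the data shown here, no measured pair speaks to replacing the phenyl by a ring with two nitrogens. The shortening of the chain and the new ring are therefore both unanchored, and a somewhat higher number is expected for compound 4, with wide uncertainty. Compound 4 is estimated at 450 nM (range 120 nM to 1800 nM), a step of a 3.0-fold higher number from compound 3 to compound 4 (0.48 log units; beyond the scatter) expected from compound 3.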

Compound 4, half-maximal inhibitory concentration: 94 nM
Estimate against measurement, compound 4: 4.8-fold (0.68 log units) above; measured number below the stated range.
By their numbers in this assay, from the lowest: compounds 4 and 3 (each within the scatter of the next); then compounds 1 and 2 (each within the scatter of the next).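

In this assay, putting 1-(pyrimidin-5-yl)ethyl in place of 1-phenylpropyl on the sulfur gives a 1.6-fold lower number from compound 3 to compound 4 (0.20 log units; within the scatter), so the two compounds cannot be told apart on this read-out. The earlier compounds shown here all carried a ring of carbon only at this position, whereas compound 4 shows that a six-membered aromatic ring with 2 hetero atoms and 2 hydrogen-bond acceptors, in a group of 8 rather than 9 heavy atoms, is accepted here without a loss the assay can detect. Nothing available explains why the number stays within the scatter. On these data alone, the ring and the chain change together in this step, so what each contributes on its own remains open. As far as these compounds go, it is also open whether a pyridine ring or a 1-(pyrimidin-5-yl)propyl group would hold the number equally well.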